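Trimethoxybenzoate in place of methoxybenzoate on a cytotoxic ester

A few compounds are considered here, and "the series" means these few. Any claim that something is new, unique, unknown or untested is made for them only; others in the source may bear on it.

Among the measured compounds shown here, compound 1 `COC(=O)/C(=C\c1ccc(OC(=O)c2ccccc2OC)cc1)Sc1ccnc2cc(Cl)ccc12` is the only compound with a number in a functional assay on Jurkat E6.1 cells (Homo sapiens) for cytotoxicity, read by MTT assay, with a stated time of 24 h; on this read-out higher numbers stand for weaker inhibition and lower numbers for stronger inhibition: compound 1 gives 44700 nM. Compound 2 `COC(=O)/C(=C\c1ccc(OC(=O)c2cc(OCc3ccccc3)c(OCc3ccccc3)c(OCc3ccccc3)c2)cc1)Sc1ccnc2cc(Cl)ccc12` reaches only the assay's limit, > 100000 nM, so that compound 2 gives no number. Compound 3 `COC(=O)/C(=C\c1ccc(OC(=O)c2cc(OC)c(OC)cc2OC)cc1)Sc1ccnc2cc(Cl)ccc12` carries 2,4,5-trimethoxyphenyl in place of 2-methoxyphenyl on a carbonyl carbon. For the measured compounds named here, since no measured pair separates by one change, the step from compound 1 to compound 3 is expected to be small, a 1.3-fold higher number from compound 1 to compound 3 (0.13 log units; within the scatter), toward weaker inhibition but within scatter. Compound 3 is therefore expected at 60000 nM, between 25000 nM and 150000 nM.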

Compound 3, half-maximal inhibitory concentration: 9650 nM
Estimate against measurement, compound 3: 6.2-fold (0.79 log units) above; measured number below the stated range.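

In this assay the exchange of 2-methoxyphenyl for 2,4,5-trimethoxyphenyl on the carbonyl carbon gives a 4.6-fold lower number from compound 1 to compound 3 (0.67 log units; beyond the scatter) toward stronger inhibition. Among the compounds shown here, this is the first measured pair differing in one place, and it shows that this group alone can move the number beyond the scatter. Compound 2 gives a limit rather than a number, so it adds no such step: the limit of > 100000 nM in this assay, at which 1 of the 3 values shown sits.

Which of the methoxy groups accounts for the step remains open. So does the outcome of placing an amine or a carboxylic acid on this ring.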